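Two Chlorines in Place of One on the Benzamide Ring

A few compounds are considered here, and "the series" means these few. Any claim that something is new, unique, unknown or untested is made for them only; others in the source may bear on it.

Compound 1 `CNC(=O)c1cc(Oc2ccc3nc(NC(=O)c4ccc(Cl)cc4)sc3c2)ccn1` was tested in a functional assay on HCT-116 cells (Homo sapiens) for inhibition, read by MTT assay, with a stated time of 2 days, tested at 10 uM (on this read-out lower numbers stand for less inhibition of growth and higher numbers for more inhibition of growth at the one concentration tested), where compound 1 gives 27.5%. Among the measured compounds shown here, the only other compound measured so far, compound 2 `CNC(=O)c1cc(Oc2ccc3nc(NC(=O)Nc4ccc(N5CCN(C)CC5)cc4)sc3c2)ccn1`, gives 24.6% in this assay, and the two numbers lie within the usual scatter of each other, so neither can be called more or less active on this evidence. For the measured compounds named here, compound 2 differs from compound 1 in several places at once, so no single structural step between measured compounds can be read off. Compound 3 `CNC(=O)c1cc(Oc2ccc3nc(NC(=O)c4cc(Cl)cc(Cl)c4)sc3c2)ccn1` has not yet been measured. It differs from compound 1 in one place: 3,5-dichlorophenyl in place of 4-chlorophenyl on a carbonyl carbon. Because nothing measured here separates the two values beyond the scatter, no direction for this change can be drawn from the data, and the step is expected to be small or absent, as in a number 2.5 percentage points higher from compound 1 to compound 3 (within the scatter). Compound 3 is therefore estimated at 30%, with a likely range from 10% to 55%.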

Compound 3, percent growth inhibition at one concentration: 13.4%
The estimate for compound 3 lay 16.6 percentage points above the measured number; the range from low to high includes it.
By their numbers in this assay, from the lowest: compound 3; then compounds 2 and 1 (each within the scatter of the next).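

Among the compounds shown here, this is the first single change that can be read on its own: in this assay, 3,5-dichlorophenyl in place of 4-chlorophenyl on the carbonyl carbon gives a number 14.1 percentage points lower from compound 1 to compound 3 (beyond the scatter). The group on this carbonyl therefore does matter to the read-out, and this particular change lowers growth inhibition by a modest step at the one concentration tested. Nothing measured here explains the drop.

This single step cannot separate the effect of adding a second chlorine from the effect of changing where the chlorines sit on the ring. Also open, from the compounds shown here alone, is how this assay would respond to a plain phenyl without chlorine, or to a phenyl carrying an amine or a carboxylic acid, on the same carbonyl.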